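The source may report more compounds than this note shows. Statements on the series, on what has been measured and on what is new or still open speak of the compounds shown alone.

Compound 3 `Cc1cc(C(=O)Nc2ccc(-c3ccccc3S(N)(=O)=O)cc2)n(-c2ccc3onc(N)c3c2)n1` is the reference for this comparison. In an assay on isolated protein for inhibition of Trypsin (Homo sapiens) (a higher number here means a weaker inhibitor, a lower number a stronger inhibitor), compound 3 gives > 1600 nM, which is a limit of the assay and not a number. Compound 1 `Cc1cc(C(=O)Nc2ccc(-c3ccccc3S(N)(=O)=O)cc2)n(-c2cccc(N)c2)n1` gives > 1600 nM, likewise a limit. Compound 2 `Cc1cc(C(=O)Nc2ccc(-c3ccccc3S(N)(=O)=O)cc2)n(-c2cccc(C(N)=O)c2)n1` gives > 1600 nM, again a limit. The steps a step that the two limits leave unreadable from compound 1 to compound 2, a step that the two limits leave unreadable from compound 1 to compound 3 and a step that the two limits leave unreadable from compound 2 to compound 3 therefore have no readable size, because of the limit of > 1600 nM in this assay, at which 3 of the 3 values shown sit. Compound 4 `Cc1cc(C(=O)Nc2ccc(-c3ccccc3S(N)(=O)=O)cc2)n(-c2ccc3c(N)[nH]nc3c2)n1` differs from compound 3 by a group of 10 heavy atoms (7 carbon, 3 nitrogen; one five-membered aromatic ring with 2 hetero atoms, one six-membered aromatic ring of carbon only) in place of a group of 10 heavy atoms (7 carbon, 2 nitrogen, 1 oxygen; one five-membered aromatic ring with 2 hetero atoms, one six-membered aromatic ring of carbon only), on an aromatic nitrogen. Within the data shown here, none of the measured steps gives a readable size for a change of this kind, so no direction beyond the scatter can be drawn from them. Compound 4 is expected to give 3000 nM, estimated between 1000 nM and 10000 nM, which would mean an expected step that the limit leaves unreadable from compound 3 to compound 4.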

Compound 4, inhibition constant: > 1600 nM
Compound 4: a limit, no number; the forecaster's own chance of this, stated with the estimate: 85%; the middle value lies beyond the limit too.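

No step between compound 4 and compound 1, compound 2 or compound 3 can be read, because all four compounds sit at the same limit, which is not a number: the limit of > 1600 nM in this assay, at which 4 of the 4 values shown sit.

The compounds shown leave open whether the groups on the aromatic nitrogen differ at all in this assay.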